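This account rests on a few compounds, and the source may have more. Where it says the series, first, only, none or still open, it means among the compounds named here.

Measured in a functional assay on DU-145 cells (Homo sapiens) for inhibition, read by trypan blue exclusion, with a stated time of 96 h; a lower number here means a stronger inhibitor of growth, a higher number a weaker inhibitor of growth:
Compound 1 `O=C(O)c1ccc(C(=O)/C(=C\c2ccc(Br)cc2)SCc2ccc(F)cc2)cc1`: > 100000 nM (a limit of the assay)
Compound 2 `O=C(O)c1ccc(C(=O)/C(=C\c2ccc(Cl)c([N+](=O)[O-])c2)SCc2ccc(Br)cc2)cc1`: 500 nM
Compound 3 `CN1CCN(/C=C(/SCc2ccc(Br)cc2)C(=O)c2ccc(C(=O)O)cc2)CC1[N+](=O)[O-]`: 10000 nM

Only two of these results are actual numbers. Compound 3 has the higher of them at 10000 nM, while compound 2 gives 500 nM. The third result is the limit of > 100000 nM in this assay, at which 1 of the 3 values shown sits.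

Compound 4 `O=C(O)c1ccc(C(=O)/C(=C\c2ccc(Br)cc2)SCc2ccc(Br)cc2)cc1` has not yet been measured. It differs from compound 3 as follows: 4-bromophenyl in place of 4-methyl-3-nitropiperazin-1-yl on a double-bonded chain carbon bound to a double-bonded chain carbon. In short, 4-bromophenyl stands in place of 4-methyl-3-nitropiperazin-1-yl on a double-bonded chain carbon bound to a double-bonded chain carbon.

Going by the values given here, the one measured step that bears on this change is large: a 20-fold higher number from compound 2 to compound 3 (1.30 log units; beyond the scatter). It introduced the same 4-methyl-3-nitropiperazin-1-yl in place of 4-chloro-3-nitrophenyl, so removing that group in favour of an aromatic ring points towards a lower number. However, the entering group here is 4-bromophenyl, not 4-chloro-3-nitrophenyl, so a full reversal of that step cannot be assumed. Compound 1, which also carries 4-bromophenyl, reports only a limit, > 100000 nM.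

A smaller move towards a lower number is therefore expected, with considerable uncertainty in both directions. The expected change is a 2.5-fold lower number from compound 3 to compound 4 (0.40 log units; beyond the scatter). Compound 4 is estimated at 4000 nM, with an expected range from 500 nM to 40000 nM.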

Compound 4, concentration for 50% growth inhibition: 1000 nM
For compound 4 the middle estimate is 4.0-fold (0.60 log units) above the measured one; low and high end bracket the measured number.
By their numbers in this assay, from the lowest: compounds 2 and 4 (each within the scatter of the next); then compound 3. At a limit, above all of these: compound 1.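

In this assay, 4-bromophenyl on a double-bonded chain carbon bound to a double-bonded chain carbon gives a 10-fold lower number from compound 3 to compound 4 (1.00 log units; beyond the scatter), so the earlier gap between the aromatic and the piperazine groups at this place no longer rests on compound 2 alone. With 4-bromophenyl in place of 4-chloro-3-nitrophenyl there is a 2.0-fold higher number from compound 2 to compound 4 (0.30 log units; within the scatter), so compound 2 and compound 4 cannot be told apart here, and the chloro and nitro groups of compound 2 are not required for a number in this range. Bromo in place of fluoro on an aromatic carbon gives an at least 100-fold lower number from compound 1 to compound 4 (2.00 log units; beyond the scatter), a step that starts from the limit of compound 1 and not from a number: the limit of > 100000 nM in this assay, at which 1 of the 4 values shown sits.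

The compounds shown leave open whether the gap to compound 3 belongs to the saturated ring or to its nitro group, which a 4-methylpiperazin-1-yl without the nitro group could separate. From the compounds shown here alone, how an unsubstituted phenyl at this place, or an ester or amide in place of the shared carboxylic acid, would read in this assay also remains open.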